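Changing the Terminal Group in a Bile Acid Receptor Series

The source may hold more compounds than are shown below. What is called first, only, known or untested is meant among the compounds shown, and "the series" means these compounds.

Measured compounds:
Compound 1 `CC(C)(C)c1ccc(C(=O)NCc2ccc(-c3nnn[nH]3)cc2)cc1` gives 120 nM in an assay on HeLa cells with Bile acid receptor (Homo sapiens) as the target, read by a luciferase reporter, with a stated time of 24 h; a higher number here means that more compound is needed for the effect, a lower number that less compound is needed.
Compound 2 `CN(C)C(=O)c1ccc(CNC(=O)c2ccc(C(C)(C)C)cc2)cc1` gives 170 nM in this assay.

Going by the values given here, compound 2 has the highest of the two numbers measured so far, yet the gap to compound 1 is small: a 1.4-fold higher number from compound 1 to compound 2 (0.15 log units; within the scatter). The step to compound 3 `CC(C)(C)c1ccc(C(=O)NCc2ccc(SC(F)(F)F)cc2)cc1` again changes only the group at one end of the shared core: (trifluoromethyl)sulfanyl in place of dimethylcarbamoyl on an aromatic carbon. Among the compounds with values here, the only measured step that bears on this end of the molecule is the one from compound 1 to compound 2, which stayed within the scatter even though the group there was replaced entirely. On that basis no change beyond the scatter is expected in this assay for compound 3, with a mildly higher number the more likely direction: a 1.3-fold higher number from compound 2 to compound 3 (0.11 log units; within the scatter). Compound 3 is therefore estimated at 220 nM, within a range of 70 nM to 700 nM.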

Compound 3, half-maximal effective concentration: 0.4 nM
Compound 3: the middle estimate sits 550-fold (2.74 log units) above what was measured, outside the stated range (below it).
By their numbers in this assay, from the lowest: compound 3; then compounds 1 and 2 (each within the scatter of the next).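

In this assay the group on this aromatic carbon turns out to matter greatly: the change gives a 430-fold lower number from compound 2 to compound 3 (2.63 log units; beyond the scatter) and, against the tetrazole, a 300-fold lower number from compound 1 to compound 3 (2.48 log units; beyond the scatter) in place of the near-equal numbers of the earlier pair. So the small step between compound 1 and compound 2 did not mean that this position tolerates any group. Dimethylcarbamoyl and (trifluoromethyl)sulfanyl have the same heavy-atom count, and neither has a ring or a net charge, so the large step comes with a change of atoms rather than of these counts, and nothing measured here accounts for it.

As far as these compounds go, whether the sulfur or the fluorines matter more remains open, and a methylsulfanyl, trifluoromethyl or trifluoromethoxy group at this place would help separate them. Also open, from the compounds shown here alone, is whether a smaller substituent, such as a single chlorine atom, would give a low number too.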